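Extending Compound 2 at the Saturated Chain Carbon

A few compounds are considered here, and "the series" means these few. Any claim that something is new, unique, unknown or untested is made for them only; others in the source may bear on it.

Measured so far:
compound 1, `NC(=O)CC[C@H](NC(=O)CN(c1ncnc2c1ncn2C1CCCCO1)C1CC1)C(=O)OCc1ccccc1`, 37.8%
compound 2, `O=C(CN(c1nc(Cl)nc2[nH]cnc12)C1CC1)NCC(=O)OCc1ccccc1`, 27.2%

Of the compounds shown here, two have been measured in a functional assay on the whole organism (Tail, strain ICR) with Mus musculus as the target, in the tail flick test, with a stated time of 90 min, at a dose of 25 umol/kg by the oral route; a higher number here means a stronger effect of the compound at the dose given, a lower number a weaker effect. Compound 1, `NC(=O)CC[C@H](NC(=O)CN(c1ncnc2c1ncn2C1CCCCO1)C1CC1)C(=O)OCc1ccccc1`, gives 37.8%. Compound 2, `O=C(CN(c1nc(Cl)nc2[nH]cnc12)C1CC1)NCC(=O)OCc1ccccc1`, gives 27.2%, the lower of the two numbers, and the gap to compound 1 lies beyond the usual scatter. The two compounds differ in more than one place, so nothing is singled out as the cause of that gap; only the two values themselves are known.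

Compound 3, `N=C(N)NCCC[C@H](NC(=O)CN(c1nc(Cl)nc2[nH]cnc12)C1CC1)C(=O)OCc1ccccc1`, has not yet been measured. It is derived from compound 2 by a single change: a group of 7 heavy atoms (4 carbon, 3 nitrogen; no ring) in place of a hydrogen atom, on a saturated chain carbon bound to an amide-type nitrogen and a carbonyl carbon. Compound 1 carries a substituent at the same kind of position, and its value in this assay is the higher of the two measured. On that slender basis, a modest rise from compound 2 is expected for compound 3, with the expected step being a number 8.8 percentage points higher from compound 2 to compound 3 (within the scatter), though a step within the scatter would not be surprising. Compound 3 is therefore estimated at 36%, with a range from 18% to 55%.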

Compound 3, a percentage reported as activity, at one dose (the size of the read-out at that dose, not a potency): 30.4%
Compound 3: middle estimate off by 5.6 percentage points, on the high side, and the stated range covers the measured number.
By their numbers in this assay, from the lowest: compounds 2, 3 and 1 (each within the scatter of the next, the first and the last beyond it).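

In this assay, among these compounds, compound 2 and compound 3 form the first pair that differs in one place, so this position can now be read directly: a group of 7 heavy atoms (4 carbon, 3 nitrogen; no ring) in place of a hydrogen atom, on a saturated chain carbon bound to an amide-type nitrogen and a carbonyl carbon, gives a number 3.2 percentage points higher from compound 2 to compound 3 (within the scatter). The read-out at this dose therefore shows no step beyond the scatter for this change, neither a gain nor a loss, although the entering group brings 3 hydrogen-bond donors and no ring. Compound 1 differs from compound 2 in more than one place, so it cannot be set beside this step, and no measurement available here bears on why the change leaves the read-out within the scatter.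

Going by these compounds, it remains open whether a methyl group, a shorter chain ending in an amine, or a chain ending in a carboxylic acid on this same carbon would give a step beyond the scatter. Also open, on these data alone, is whether the same group would read the same way on the core of compound 1.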